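The source may hold more compounds than are shown below. What is called first, only, known or untested is meant among the compounds shown, and "the series" means these compounds.

Compound 2 `COC(=O)c1c[nH]c([C@@H](O)c2ccccc2)cc1=O` and compound 1 `NC(=O)c1c[nH]c([C@@H](O)c2ccccc2)cc1=O` share one core and differ at a single carbonyl carbon, where a methoxy replaces an amino. In a functional assay on A549 cells (Homo sapiens) for inhibition, read by sulforhodamine B assay, with a stated time of 48 h (a lower number here means a stronger inhibitor, a higher number a weaker inhibitor), compound 1 gives > 50000 nM, which is a limit of the assay rather than a number. In this assay compound 2 gives > 50000 nM, again a limit and not a number. The step that the two limits leave unreadable from compound 1 to compound 2 therefore cannot be read, and compound 2 stands only at a limit, with no measured number to place it.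

Compound 3 `CC(C)CC(=O)NC(=O)c1c[nH]c([C@@H](O)c2ccccc2)cc1=O` is changed from compound 2 by (isobutylcarbonyl)amino in place of methoxy on a carbonyl carbon. Among the compounds with values here, the one measured step, from compound 1 to compound 2, is the unreadable one, so nothing measured shows what exchanging the group on this carbonyl carbon does in this assay. Because the limit of > 50000 nM in this assay, at which 2 of the 2 values shown sit, describes both values shown, no step beyond the scatter can be expected in either direction.

Compound 3 is therefore estimated at 50000 nM, within 15000 nM to 150000 nM, most likely reported again as a limit. The expected step is a number no higher from compound 2 to compound 3 (the limit leaves the size open), none beyond the scatter.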

Compound 3, half-maximal inhibitory concentration: > 50000 nM
Compound 3: a limit, no number; the forecaster's own chance of this, stated with the estimate: 75%; the middle value sits exactly at the limit.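

In this assay compound 3 gives > 50000 nM, which is a limit of the assay and not a number, so the steps to it from compound 1 and from compound 2 cannot be read. The compounds shown leave open how strongly each inhibits and whether the group on this carbonyl carbon changes the result at all, with one boundary covering them all: the limit of > 50000 nM in this assay, at which 3 of the 3 values shown sit.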